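Replacing the Oxanylmethyl Amide with a Piperidine Urea

The source may hold more compounds than are shown below. What is called first, only, known or untested is meant among the compounds shown, and "the series" means these compounds.

Half-lives measured in an ADME assay (liver) for metabolic stability, with Liver microsome (Homo sapiens) as the target, read by LC-MS, using microsomes and NADPH, tested at 1 uM; on this read-out lower numbers stand for a shorter-lived compound and higher numbers for a longer-lived compound:
Compound 1 `CC(C)(C)c1cc(NC(=O)[C@@H]2CCCCN2CC2CCOCC2)no1` gives 0.183 h.
Compound 2 `CC(C)(C)c1cc(NC(=O)[C@@H]2CCCCN2C(=O)C2CCOCC2)no1` gives > 2 h, which is a limit of the assay and not a number.
Compound 3 `CC(C)(C)c1cc(NC(=O)[C@@H]2CCCCN2C(=O)CC2CCOCC2)no1` gives 1.83 h.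

For the measured compounds named here, compound 3 holds the highest of the two numbers known. Its nearest neighbour is compound 1, and the step between them is a 10-fold higher number from compound 1 to compound 3 (1.00 log units; beyond the scatter). The remaining value, that of compound 2, is a limit (the limit of > 2 h in this assay, at which 1 of the 3 values shown sits).

Compound 4 `CC(C)(C)c1cc(NC(=O)[C@@H]2CCCCN2C(=O)N2CCCCC2)no1` differs from compound 3 by piperidin-1-yl in place of (oxan-4-yl)methyl on a carbonyl carbon. Going by the values given here, the one measured step that touches the same carbonyl carbon is an at least 1.0-fold lower number from compound 2 to compound 3 (0.03 log units; that floor lies within the scatter), so exchanging one ring-bearing group for another at that place left the read-out unchanged, as far as the limit allows one to judge. Both acylated compounds stand well apart from compound 1: an at least 10-fold higher number from compound 1 to compound 2 (1.03 log units; beyond the scatter) and a 10-fold higher number from compound 1 to compound 3 (1.00 log units; beyond the scatter). Among the compounds with values here, no measured pair shows a piperidin-1-yl on this carbonyl carbon, so the change itself is untested. Compound 4 is therefore expected to remain close to compound 3, with a 1.0-fold lower number from compound 3 to compound 4 (0.01 log units; within the scatter) no larger than the scatter. The estimate for compound 4 in this assay is 1.8 h, expected to lie between 0.9 h and 3.6 h.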

Compound 4, half-life: 0.233 h
Estimate against measurement, compound 4: 7.7-fold (0.89 log units) above; measured number outside the range, below it.
By their numbers in this assay, from the lowest: compounds 1 and 4 (each within the scatter of the next); then compound 3. At a limit, above all of these: compound 2.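

The group on this carbonyl carbon proves decisive in this assay: the read-out shows a 7.9-fold lower number from compound 3 to compound 4 (0.90 log units; beyond the scatter) and also an at least 8.5-fold lower number from compound 2 to compound 4 (0.93 log units; beyond the scatter), so the two compounds carrying an oxan-4-yl ring stand clearly apart from the piperidin-1-yl compound. The earlier compounds shown here could suggest that a carbonyl on the ring amine nitrogen was enough for a long half-life, but compound 4 goes against that reading, with a 1.3-fold higher number from compound 1 to compound 4 (0.10 log units; within the scatter), which leaves it level with the compound that has no such carbonyl. The second of these comparisons rests on a limit and not a number, which belongs to compound 2: the limit of > 2 h in this assay, at which 1 of the 4 values shown sits.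

The compounds shown give no measured reason for the shorter half-life of compound 4. They also leave open whether the ring oxygen or the ring nitrogen attached to the carbonyl carbon decides the outcome, a question that a morpholin-4-yl or a cyclohexyl group at this place could separate.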